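The source may report more compounds than this note shows. Statements on the series, on what has been measured and on what is new or still open speak of the compounds shown alone.

Compound 1 `CCSc1nc2cc(S(=O)(=O)NCc3ccc(Cl)cc3)ccc2n1Cc1ccccc1` gives 280 nM in an assay on isolated protein for inhibition of Gonadotropin-releasing hormone receptor (Homo sapiens) (on this read-out higher numbers stand for weaker inhibition and lower numbers for stronger inhibition), and compound 2 `CCSc1nc2cc(S(=O)(=O)NCc3ccc(F)cc3)ccc2n1Cc1ccccc1` gives 250 nM in this assay. Compound 3 `CSc1nc2cc(S(=O)(=O)NCc3ccc(F)cc3)ccc2n1Cc1ccccc1` gives 220 nM in this assay and sits at the low end of the three numbers, though its gaps to compound 2 and to compound 1 both stay within the scatter. The steps seen so far, a 1.1-fold lower number from compound 1 to compound 2 (0.05 log units; within the scatter) and a 1.1-fold lower number from compound 2 to compound 3 (0.06 log units; within the scatter), were both small. Compound 4 `O=S(=O)(NCc1ccc(F)cc1)c1ccc2c(c1)nc(SCCO)n2Cc1ccccc1` differs from compound 3 by hydroxymethyl in place of hydrogen on a saturated chain carbon bound to a sulfur. Only the second step touches the same place, and it stayed within the scatter, so compound 4 is expected to show a 1.1-fold higher number from compound 3 to compound 4 (0.06 log units; within the scatter), no step beyond the scatter. The estimate for compound 4 is therefore 250 nM, within 100 nM to 600 nM.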

Compound 4, half-maximal inhibitory concentration: 270 nM
For compound 4 the middle estimate is 1.1-fold (0.03 log units) below the measured one; low and high end bracket the measured number.
By their numbers in this assay, from the lowest: compounds 3, 2, 4 and 1 (each within the scatter of the next).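

Across the change to (2-hydroxyethyl)sulfanyl, this assay shows a 1.2-fold higher number from compound 3 to compound 4 (0.09 log units; within the scatter) for hydroxymethyl in place of hydrogen. Hydroxy in place of hydrogen on the chain gives a 1.1-fold higher number from compound 2 to compound 4 (0.03 log units; within the scatter) as the smaller comparison, so this position, so far tried only with plain chains, also takes a chain bearing hydroxy without a step beyond the scatter. Nothing available explains why these numbers stay so close. On these data alone, whether an amine or a carboxylic acid on this chain, or a longer chain, would bring a step beyond the scatter stays open.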